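From 3-Methoxyphenyl to 3,5-Difluorophenyl on a Shared Core

The compounds below may be only part of what the source reports. "The series", "measured", "known", "first", "only" and "open" are said of these compounds alone.

In a functional assay on HL-60 cells (Homo sapiens) for inhibition, read by MTT assay, with a stated time of 72 h (on this read-out higher numbers stand for weaker inhibition and lower numbers for stronger inhibition), compound 1 `COc1cccc(N2CCN(C(=O)c3oc(C)nc3-c3ccccc3F)CC2)c1` gives 56.1 nM, compound 2 `COc1cccc(N2CCN(C(=O)c3oc(C)nc3-c3ccc(F)cc3)CC2)c1` gives 112 nM and compound 3 `COc1cccc(N2CCN(C(=O)c3oc(C)nc3-c3ccccc3)CC2)c1` gives 34.8 nM. Compound 1 holds the middle of these three numbers, but its gaps to the other two lie within the scatter: a 1.6-fold lower number from compound 1 to compound 3 (0.21 log units; within the scatter) and a 2.0-fold higher number from compound 1 to compound 2 (0.30 log units; within the scatter).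

Compound 4 `Cc1nc(-c2ccccc2F)c(C(=O)N2CCN(c3cc(F)cc(F)c3)CC2)o1` departs from compound 1 at a single place, with 3,5-difluorophenyl in place of 3-methoxyphenyl on an amine nitrogen in a ring. Going by the values given here, no measured step touches that place, since all of them concern a fluoro elsewhere in the molecule. They offer only a rough guide to size, and the largest of them, a 3.2-fold lower number from compound 2 to compound 3 (0.51 log units; beyond the scatter), is modest. The data give no direction for the new change, so only a small step is expected in this assay, and the estimate is a 1.2-fold higher number from compound 1 to compound 4 (0.10 log units; within the scatter). For compound 4 the expected value is 70 nM, with an estimated range from 20 nM to 250 nM.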

Compound 4, half-maximal inhibitory concentration: 186 nM
Beside the measured number, compound 4's estimate is 2.7-fold (0.42 log units) below it; measured number inside the range.
By their numbers in this assay, from the lowest: compounds 3, 1, 2 and 4 (each within the scatter of the next, the first and the last beyond it).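

The exchange of 3-methoxyphenyl for 3,5-difluorophenyl gives the first measured view of this place on the shared core, and in this assay it goes towards weaker inhibition (a 3.3-fold higher number from compound 1 to compound 4 (0.52 log units; beyond the scatter)). The place is therefore not silent on this read-out, and this modest step is about as large as the largest fluoro step measured elsewhere in the molecule (a 3.2-fold lower number from compound 2 to compound 3 (0.51 log units; beyond the scatter)). No evidence at hand bears on what lies behind the step.

From the compounds shown here alone, with only these two groups seen at this place, it remains open whether the step comes from losing the methoxy group or from gaining the two fluoro groups. Going by these compounds, it is also open how a phenyl ring carrying a single fluoro, a hydroxyl or an amine would read here, and whether the step would carry over to the core of compound 3.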